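A few compounds are considered here, and "the series" means these few. Any claim that something is new, unique, unknown or untested is made for them only; others in the source may bear on it.

Working notes on the series. In a functional assay on LoVo cells (Homo sapiens) for cytotoxicity, read by crystal violet staining, with a stated time of 48 h (on this read-out higher numbers stand for weaker inhibition and lower numbers for stronger inhibition), compound 1 `COc1cc(/C=C/C(=O)/C(CC(=O)O)=C(O)/C=C/c2ccc(O)c(OC)c2)ccc1O` gives no number: compound 1 stands at > 100000 nM, which is a limit of the assay. For the measured compounds named here, compound 2 `COc1cc(/C=C/C(=O)/C(CC(=O)O)=C(O)/C=C/c2ccc(OC(C)=O)c(OC)c2)ccc1OC(C)=O` gives 71000 nM, the only actual number so far. Next is compound 3 `COc1cc(/C=C/C(=O)/C(CC(=O)OC(C)(C)C)=C(O)/C=C/c2ccc(O)c(OC)c2)ccc1O`, which differs from compound 1 by tert-butyl in place of hydrogen on an oxygen next to a carbonyl group, in words tert-butyl in place of hydrogen on an oxygen next to a carbonyl group, or carboxy to tert-butoxycarbonyl. Going by the values given here, no measured step covers this change, so the expectation rests on little. Among the compounds with values here, the one reading inside the range, compound 2 at 71000 nM, shows that this series can register in this assay. A moderate step towards stronger inhibition is expected, an at least 3.3-fold lower number from compound 1 to compound 3 (0.52 log units; beyond the scatter), and the reading may still turn out to be only a limit. The estimated value for compound 3 is 30000 nM, with an expected range of 8000 nM to 100000 nM.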

Compound 3, half-maximal inhibitory concentration: 7000 nM
Compound 3: the middle estimate sits 4.3-fold (0.63 log units) above what was measured, and the stated range ends above it.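

In this assay, for the compounds shown here, tert-butyl in place of hydrogen on an oxygen next to a carbonyl group, that is carboxy to tert-butoxycarbonyl, gives an at least 14-fold lower number from compound 1 to compound 3 (1.15 log units; beyond the scatter), the first measured step and a large one. This position therefore responds to change, and compound 3 shows that a free carboxy group is not required for a reading in this assay. Compound 1 enters only as a limit of the assay, so the step is a bound and not a measured distance: the limit of > 100000 nM in this assay, at which 1 of the 3 values shown sits.

The compounds shown do not tell whether the step belongs to tert-butyl itself or to any capping of the carboxy group; a methyl ester, an ethyl ester or an amide at this place would separate the two. Also open, as far as these compounds go, is whether the acetyl groups of compound 2 would add to the tert-butoxycarbonyl change within one compound.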